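The compounds below may be only part of what the source reports. "The series", "measured", "known", "first", "only" and "open" are said of these compounds alone.

Compound 1, `O[C@@H]1[C@H](O)CS[C@H]1Cn1cnc2c(NCc3cccc(Br)c3)ncnc21`: 6.1%
Compound 2, `O[C@@H]1[C@H](O)CS[C@H]1Cn1cnc2c(NCc3cccc(I)c3)nc(Cl)nc21`: 10%

Both measured compounds were tested in an assay on CHO cells for displacement of a labelled ligand from adenosine receptor A3 (Homo sapiens), with a stated time of 60 min, tested at 10 uM; on this read-out lower numbers stand for less inhibition and higher numbers for more inhibition at the one concentration tested (going by the name of the read-out). Compound 1 gives 6.1%. Compound 2 gives 10%, a reading that lies within the usual scatter of the result for compound 1, so the two cannot be told apart; both sit near the bottom of the scale, where little of the labelled ligand is displaced at the one concentration tested. Going by the values given here, no pair of measured compounds differs in a single place, so no measured step is available for this assay.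

Compound 3, `O[C@@H]1[C@H](O)CS[C@H]1Cn1cnc2c(NCc3cccc(Cl)c3)nc(Cl)nc21`, has not yet been measured. It is reached from compound 2 by one change: chloro in place of iodo on an aromatic carbon. The change swaps one halogen for another on an aromatic carbon, with nothing added or removed in the way of rings, hydrogen-bond donors, acceptors or charge. With both measured compounds reading low and indistinguishable, the step of a number 2 percentage points lower from compound 2 to compound 3 (within the scatter) is expected to be small, in no clear direction, and not beyond the scatter. Compound 3 is therefore expected to give about 8%, most likely between 0% and 25%.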

Compound 3, a percentage reported as inhibition, at one concentration (the size of the read-out at that concentration, not a potency): 13.6%
The estimate for compound 3 lay 5.6 percentage points below the measured number, within the range that was stated.
By their numbers in this assay, from the lowest: compounds 1, 2 and 3 (each within the scatter of the next).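

Going by these compounds alone, this is the first step in this assay where only one place changes, and it gives a number 3.6 percentage points higher from compound 2 to compound 3 (within the scatter). At this position on the benzyl group, then, going from 3-iodobenzyl to 3-chlorobenzyl swaps one halogen for another without a readable effect, and compound 3, at 13.6%, stays near the low end of the scale, where little of the labelled ligand is displaced. Nothing measured here offers an explanation for this result.

The compounds shown carry only a halogen at this position, so they leave open how a group of a different kind, such as an amine, a carboxylic acid or a longer chain, would read there. Compound 1 differs from compound 3 in two places, the halogen on the benzyl group and the chloro on the shared core, so the part played by that core chloro also remains open, as does whether any of these compounds would show more displacement at a higher concentration.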